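The compounds below may be only part of what the source reports. "The series", "measured", "known", "first", "only" and "open" are said of these compounds alone.

Working notes on the series in a functional assay on HCT-116 cells (Homo sapiens) for cytotoxicity, read by resazurin assay, with a stated time of 48 h; on this read-out higher numbers stand for an effect only at larger amounts of compound and lower numbers for an effect already at smaller amounts. Of the compounds shown here, three have been measured so far. Compound 1 `O=C(/C=C/c1ccco1)c1ccc(NC(=O)c2cccs2)cc1` gives 33000 nM. Compound 2 `CC(=O)Nc1ccc(C(=O)/C=C/c2cccc([N+](=O)[O-])c2)cc1` gives 1700 nM. Compound 3 `O=C(/C=C/c1cccc([N+](=O)[O-])c1)c1ccc(NC(=O)c2ccco2)cc1` gives 3400 nM, the second highest of the three numbers. Within the data shown here, its nearest neighbour is compound 2: the single measured step, a 2.0-fold higher number from compound 2 to compound 3 (0.30 log units; within the scatter), is within the scatter. Its furthest is compound 1, whose number is higher beyond the scatter; the two differ in more than one place, so the gap cannot be assigned to any one change.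

Compound 4 `O=C(/C=C/c1cccc([N+](=O)[O-])c1)c1ccc(NC(=O)c2cccs2)cc1` is the next step from compound 3: thiophen-2-yl in place of furan-2-yl on a carbonyl carbon. Among the measured compounds shown here, no measured step bears directly on this exchange. For the measured compounds named here, the one measured step, from compound 2 to compound 3, concerns a different exchange at the same carbonyl carbon and was within the scatter. Compound 1 carries the thiophen-2-yl carbonyl, but the rest of its structure differs from compound 4 as well, so its value does not isolate the exchange. On this basis no step beyond the scatter is expected in this assay, in either direction; compound 4 is estimated to lie at no change at the digits printed from compound 3 to compound 4 (within the scatter) from compound 3. For compound 4 the estimated value is 3400 nM, with a range from 1500 nM to 8000 nM.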

Compound 4, half-maximal effective concentration: 2600 nM
Beside the measured number, compound 4's estimate is 1.3-fold (0.12 log units) above it; the range from low to high includes it.
By their numbers in this assay, from the lowest: compounds 2, 4 and 3 (each within the scatter of the next); then compound 1.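

In this assay, thiophen-2-yl in place of furan-2-yl on a carbonyl carbon bound to the amide-type nitrogen gives a 1.3-fold lower number from compound 3 to compound 4 (0.12 log units; within the scatter), and thiophen-2-yl in place of methyl at the same carbon gives a 1.5-fold higher number from compound 2 to compound 4 (0.18 log units; within the scatter), so methyl, furan-2-yl and thiophen-2-yl are not told apart at this position among the compounds carrying 3-nitrophenyl. Among these compounds, the large gap to compound 1 can now be assigned to one change: 3-nitrophenyl in place of furan-2-yl on a double-bonded chain carbon bound to a double-bonded chain carbon gives a 13-fold lower number from compound 1 to compound 4 (1.10 log units; beyond the scatter), the only step here beyond the scatter that maps to a single place. Nothing on hand accounts for either the small steps at the carbonyl carbon or the large step at the chain carbon.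

Open, from the compounds shown here alone, is whether an amine or a longer alkyl chain on the carbonyl carbon would give a step beyond the scatter, and whether the furan-2-yl to thiophen-2-yl exchange stays within the scatter with furan-2-yl on the chain carbon. Also open, going by these compounds, is whether the large step belongs to the nitro group or to the phenyl ring, a question that a plain phenyl or an aminophenyl on that chain carbon would address.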